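One double bond, redrawn from Z to E

The source may hold more compounds than are shown below. What is called first, only, known or untested is meant among the compounds shown, and "the series" means these compounds.

Compound 1 `CCCCCCCC/C=C/CCCCCCCCOC[C@@H]1C[C@@H](O)CN1C(=O)OC(C)(C)C` gives 29500 nM
Compound 2 `CCCCCCCC/C=C\CCCCCCCCOC[C@@H]1C[C@@H](O)CN1` gives 3900 nM

In a functional assay on HeLa cells (Homo sapiens) for inhibition, with a stated time of 72 h (on this read-out higher numbers stand for weaker inhibition and lower numbers for stronger inhibition), compound 2 has the lower of the two numbers (3900 nM) and so the stronger inhibition. Compound 1 stands higher (29500 nM) and that gap lies beyond the scatter.

Compound 3 `CCCCCCCC/C=C/CCCCCCCCOC[C@@H]1C[C@@H](O)CN1` has not been measured yet. It differs from compound 2 only in configuration as drawn (the two compounds have the same atoms and bonds and differ only in configuration as drawn: 1 of 3 stereo elements differ; a double bond is drawn Z in compound 2 and E in compound 3): a double bond is drawn Z in compound 2 and E in compound 3. Among the compounds with values here, no measured pair shows what this change alone does in this assay and the same atoms and bonds remain, so no shift beyond the scatter is expected. The expected size of the change a 1.2-fold higher number from compound 2 to compound 3 (0.06 log units; within the scatter) is small, starting from compound 2 (3900 nM). For compound 3 the estimated value is 4500 nM (expected range 2000 nM to 10000 nM).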

Compound 3, half-maximal inhibitory concentration: 4000 nM
Compound 3: the middle estimate sits 1.1-fold (0.05 log units) above what was measured, within the range that was stated.
By their numbers in this assay, from the lowest: compounds 2 and 3 (each within the scatter of the next); then compound 1.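

In this assay, the step from Z to E at the double bond is a 1.0-fold higher number from compound 2 to compound 3 (0.01 log units; within the scatter), and this pair isolates the geometry of the chain, with nothing else altered: the fact that compounds 2 and 3 differ only in the configuration as drawn. The earlier gap could not be assigned to one change, since compound 1 and compound 2 differ both in that geometry and in the group on the ring nitrogen. With the E double bond held constant, putting hydrogen in place of tert-butoxycarbonyl on the amine nitrogen gives a 7.4-fold lower number from compound 1 to compound 3 (0.87 log units; beyond the scatter), a single change that accounts for a gap of about the earlier size.

From the compounds shown here alone, whether a fully saturated chain, or a shorter or longer one, would read like compound 2 and compound 3 remains open. So does where a smaller group on the ring nitrogen, such as methyl or acetyl, would fall.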